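The compounds below may be only part of what the source reports. "The series", "measured", "known", "first", "only" and "open" are said of these compounds alone.

Measured so far in a functional assay on MCF7 cells (Homo sapiens) for cytotoxicity, read by MTT assay, with a stated time of 48 h; on this read-out higher numbers stand for weaker inhibition and lower numbers for stronger inhibition:
- compound 1 `CCN(CC)C(=S)SC(CC(=O)c1ccccc1)c1ccc(C)cc1`: 20000 nM
- compound 2 `CCN(CC)C(=S)SC(CC(=O)c1ccccc1)c1ccc(Br)cc1`: 80 nM
- compound 3 `CCN(CC)C(=S)SC(CC(=O)c1ccccc1)c1ccc(Cl)cc1`: 120 nM

Compound 3 lies within the scatter of compound 2, as shown by a 1.5-fold higher number from compound 2 to compound 3 (0.18 log units; within the scatter). It lies far from compound 1, as shown by a 170-fold lower number from compound 1 to compound 3 (2.22 log units; beyond the scatter).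

The next compound is compound 4 `CCN(CC)C(=S)SC(CC(=O)c1ccccc1)c1ccc(F)cc1`, which carries fluoro in place of chloro on an aromatic carbon.

Two kinds of measured step bear on this change. The exchange between the two halogens in a 1.5-fold higher number from compound 2 to compound 3 (0.18 log units; within the scatter) stayed within the scatter, which points to a small change. Replacing methyl gave large steps in a 250-fold lower number from compound 1 to compound 2 (2.40 log units; beyond the scatter) and a 170-fold lower number from compound 1 to compound 3 (2.22 log units; beyond the scatter), so changes at this place can move the number a long way in this assay. Among the compounds with values here, no fluoro compound has been measured yet, so the upper side of the range is kept wide.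

The estimated step is a 2.5-fold higher number from compound 3 to compound 4 (0.40 log units; beyond the scatter), a modest move towards a higher number. For compound 4 the expected value is 300 nM, with an expected range of 80 nM to 3000 nM.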

Compound 4, half-maximal inhibitory concentration: 700 nM
Compound 4: the middle estimate sits 2.3-fold (0.37 log units) below what was measured; low and high end bracket the measured number.
By their numbers in this assay, from the lowest: compounds 2 and 3 (each within the scatter of the next); then compound 4; then compound 1.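

In this assay, the halogens at this place no longer behave as one group: fluoro in place of chloro gives a step beyond the scatter (a 5.8-fold higher number from compound 3 to compound 4 (0.77 log units; beyond the scatter)), as does fluoro in place of bromo (an 8.8-fold higher number from compound 2 to compound 4 (0.94 log units; beyond the scatter)), although chloro and bromo lie within the scatter of each other. Fluoro still keeps a large part of the gain over methyl (a 29-fold lower number from compound 1 to compound 4 (1.46 log units; beyond the scatter)), so across these four compounds the numbers fall from methyl to fluoro and then to chloro and bromo, with no compound going against that order. Nothing available here explains the separation of fluoro from the other two halogens.

The compounds shown leave open where iodo, methoxy, nitrile or an amine would fall at this place. They also leave open whether the same order holds when the diethylamino group of the shared core is replaced by a longer chain.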